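This account rests on a few compounds, and the source may have more. Where it says the series, first, only, none or still open, it means among the compounds named here.

Of the compounds shown here, two have been measured so far in a functional assay on MCF7 cells (Homo sapiens) for inhibition, read by MTT assay (a higher number here means a weaker inhibitor of growth, a lower number a stronger inhibitor of growth), and their numbers sit close together. Compound 1 `CC1=C(/C=C/C(C)=C/C=C/C(C)=C\C(=O)Nc2cccc(F)c2)C(C)(C)CCC1n1ccnc1` gives 5490 nM and compound 2 `CC1=C(/C=C/C(C)=C/C=C/C(C)=C\C(=O)NCc2ccc(O)cc2)C(C)(C)CC=C1c1cncnc1` gives 4960 nM there, so compound 1 stands within the usual scatter of compound 2 and the two cannot be ranked. Compound 3 `CC1=C(/C=C/C(C)=C/C=C/C(C)=C\C(=O)Nc2ccccc2O)C(C)(C)CCC1n1ccnc1` keeps the core of compound 1 and carries 2-hydroxyphenyl in place of 3-fluorophenyl on an amide-type nitrogen. Going by the values given here, no measured pair isolates a change of this kind, so its size cannot be read directly from the data. Among the compounds with values here, the only guide is indirect: compound 2 at 4960 nM differs from compound 1 in more than one place and still lies within the scatter of it. On that slender basis, no step beyond the scatter is expected in this assay, and no direction can be favoured with confidence. The estimated change is a 1.4-fold lower number from compound 1 to compound 3 (0.14 log units; within the scatter) and would be small. Compound 3 is therefore expected at 4000 nM with an estimated range of 1500 nM to 10000 nM around that figure.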

Compound 3, concentration for 50% growth inhibition: 1090 nM
Beside the measured number, compound 3's estimate is 3.7-fold (0.56 log units) above it; measured number below the stated range.
By their numbers in this assay, from the lowest: compound 3; then compounds 2 and 1 (each within the scatter of the next).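

Going by these compounds alone, the change from 3-fluorophenyl to 2-hydroxyphenyl on the amide-type nitrogen gives the first step in this assay that can be read from a single difference, a 5.0-fold lower number from compound 1 to compound 3 (0.70 log units; beyond the scatter) and so shows that the group at this position can move the number beyond the scatter, which compounds differing in more than one place could not show. The step is modest, and the entering group counts a hydrogen-bond donor and a hydrogen-bond acceptor where the leaving group counts neither, though this count alone does not tie the step to either feature. Nothing measured here bears on the reason for the step.

The change replaces the fluorine with a hydroxyl and also alters the substitution numbering on the ring, so 2-fluorophenyl or 3-hydroxyphenyl on the same nitrogen would be needed to separate those two differences. The compounds shown also leave open how 2-aminophenyl or 2-methoxyphenyl would read at this position, and whether the step would carry over to the core of compound 2.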